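Swapping the benzodioxin of compound 3 for a trifluoromethylphenyl

The compounds below may be only part of what the source reports. "The series", "measured", "known", "first", "only" and "open" are said of these compounds alone.

Compound 3 `O=S(=O)(NCCCNCC1COc2ccccc2O1)c1cc(C(F)(F)F)cc(C(F)(F)F)c1` gives the lowest number of the three measured compounds in a functional assay on HT-29 cells (Homo sapiens) for inhibition, read by MTT assay, with a stated time of 72 h (a higher number here means a weaker inhibitor of growth, a lower number a stronger inhibitor of growth), at 2200 nM. Compound 1 `O=S(=O)(NCCCNCc1ccc(Cl)c(Cl)c1)c1cc(C(F)(F)F)cc(C(F)(F)F)c1` gives 4700 nM in this assay, and compound 2 `O=S(=O)(NCCCNCc1ccc(Cl)c(C(F)(F)F)c1)c1cc(C(F)(F)F)cc(C(F)(F)F)c1` gives 11000 nM. Compound 4 `O=S(=O)(NCCCNCc1ccc(C(F)(F)F)cc1)c1cc(C(F)(F)F)cc(C(F)(F)F)c1` differs from compound 3 by 4-(trifluoromethyl)phenyl in place of 2,3-dihydro-1,4-benzodioxin-2-yl on a saturated chain carbon bound to an amine nitrogen. Among the compounds with values here, the steps that bear on this change run the other way: a 2.1-fold lower number from compound 1 to compound 3 (0.33 log units; beyond the scatter) and a 5.0-fold lower number from compound 2 to compound 3 (0.70 log units; beyond the scatter), both beyond the scatter. Replacing the benzodioxin with an aryl group is therefore expected to raise the number again in this assay, by a modest step, a 3.0-fold higher number from compound 3 to compound 4 (0.47 log units; beyond the scatter). Compound 4 is estimated at 6500 nM, with a range from 2500 nM to 17000 nM.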

Compound 4, concentration for 50% growth inhibition: 2900 nM
Compound 4: middle estimate off by 2.2-fold (0.35 log units), on the high side; measured number inside the range.
By their numbers in this assay, from the lowest: compounds 3, 4 and 1 (each within the scatter of the next, the first and the last beyond it); then compound 2.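

Compound 4 stands level with compound 3 in this assay (a 1.3-fold higher number from compound 3 to compound 4 (0.12 log units; within the scatter)), so at this position the 4-(trifluoromethyl)phenyl group matches the 2,3-dihydro-1,4-benzodioxin-2-yl group within the scatter. It also stays within the scatter of the 3,4-dichlorophenyl group (a 1.6-fold lower number from compound 1 to compound 4 (0.21 log units; within the scatter)). Only the 4-chloro-3-(trifluoromethyl)phenyl group stands apart (a 3.8-fold lower number from compound 2 to compound 4 (0.58 log units; beyond the scatter)), and no measurement here explains this. Still open, as far as these compounds go, is how an unsubstituted phenyl, a pyridine ring or a longer chain at this place would read in this assay.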